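Replacing the cyclohexylurea of compound 2 with ethylamine

A few compounds are considered here, and "the series" means these few. Any claim that something is new, unique, unknown or untested is made for them only; others in the source may bear on it.

Compound 2 `O=C(Nc1ncc(C(=O)O)c2nc(-c3ccco3)nn12)NC1CCCCC1` gives 59400 nM in an assay on CHO cells for displacement of a labelled ligand from adenosine receptor A3 (Homo sapiens) (on this read-out higher numbers stand for weaker inhibition and lower numbers for stronger inhibition), the highest of the three numbers; compound 1 `CNC(=O)c1cnc(NC(=O)NC2CCCCC2)n2nc(-c3ccco3)nc12` gives 18700 nM and compound 3 `CCOC(=O)c1cnc(NCC2CCCCC2)n2nc(-c3ccco3)nc12` gives 41.2 nM. Among the compounds with values here, the only measured single-place step is a 3.2-fold higher number from compound 1 to compound 2 (0.50 log units; beyond the scatter). Compound 4 `CCNc1ncc(C(=O)O)c2nc(-c3ccco3)nn12` differs from compound 2 by ethyl in place of cyclohexylcarbamoyl on a nitrogen on an aromatic ring. Within the data shown here, no measured step bears directly on this change: compound 3 differs from compound 2 in two places at once, so its far lower number cannot be assigned to the nitrogen substituent alone, and the carboxylic acid of compound 2 is kept in compound 4. In this assay a step of uncertain direction and wide range is expected, a 3.0-fold lower number from compound 2 to compound 4 (0.47 log units; beyond the scatter). For compound 4 the estimate is 20000 nM, between 3000 nM and 100000 nM.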

Compound 4, inhibition constant: 480 nM
Compound 4: the middle estimate sits 42-fold (1.62 log units) above what was measured, outside the stated range (below it).
By their numbers in this assay, from the lowest: compound 3; then compound 4; then compound 1; then compound 2.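

In this assay, ethyl on this nitrogen gives a 120-fold lower number from compound 2 to compound 4 (2.09 log units; beyond the scatter), a far larger step than the only earlier single-place one, a 3.2-fold higher number from compound 1 to compound 2 (0.50 log units; beyond the scatter). The nitrogen substituent therefore moves the number much further than the change on the carbonyl carbon, and the carboxylic acid, kept in compound 4, does not by itself hold the number high. No evidence on hand explains the size of this step.

Going by these compounds, it remains open whether the cyclohexyl ring or the carbamoyl link accounts for the step. Ethylcarbamoyl or a butyl chain on this nitrogen would separate the two.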